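Moving the pyridine nitrogen in a weak T47D cytotoxic series

The source may report more compounds than this note shows. Statements on the series, on what has been measured and on what is new or still open speak of the compounds shown alone.

Going by the values given here, compound 1 `Oc1cccc(-c2cc(-c3ccc(Cl)cc3)nc(-c3ccccn3)c2)c1` is the one member of this small group with a reported number. In a functional assay on T47D cells (Homo sapiens) for cytotoxicity, read by CCK-8 assay and cell counting, with a stated time of 2 days (on this read-out lower numbers stand for stronger inhibition and higher numbers for weaker inhibition), compound 1 gives 13900 nM, which places it among weak inhibitors of T47D cell growth. Among the compounds with values here, its two companions carry the chlorine at other positions of the chlorophenyl ring: in this assay compound 2 `Oc1cccc(-c2cc(-c3cccc(Cl)c3)nc(-c3ccccn3)c2)c1` gives "not determined" (no result reported), and in this assay compound 3 `Oc1cccc(-c2cc(-c3ccccn3)nc(-c3ccccc3Cl)c2)c1` likewise gives "not determined" (no result reported), so compound 1 stands alone on the numbers and no comparison between measured compounds can be drawn.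

Compound 4 `Oc1cccc(-c2cc(-c3ccncc3)nc(-c3ccc(Cl)cc3)c2)c1` is built from the same atoms as compound 1, joined differently: pyridin-4-yl in place of pyridin-2-yl on an aromatic carbon. Within the data shown here, no measured pair in this set tracks what such a change does, so the expectation for this assay can rest only on the value of compound 1 and on the fact that the rest of the molecule is untouched. The author expects the step of a 1.1-fold higher number from compound 1 to compound 4 (0.03 log units; within the scatter) to stay within, or only slightly beyond, the scatter of repeated measurements, with no clear direction favoured. Compound 4 is therefore estimated at 15000 nM in this assay, with a likely range from 5000 nM to 45000 nM, and with a real chance that a weak compound of this kind returns only a limit rather than a number.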

Compound 4, half-maximal inhibitory concentration: 3330 nM
For compound 4 the middle estimate is 4.5-fold (0.65 log units) above the measured one, outside the stated range (below it).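

Pyridin-4-yl in place of pyridin-2-yl gives a 4.2-fold lower number from compound 1 to compound 4 (0.62 log units; beyond the scatter) in this assay, so this aromatic carbon, meta to the 3-hydroxyphenyl and 4-chlorophenyl groups, responds to a change that keeps the same atoms and alters only how they are joined. Going by these compounds alone, compound 4, at 3330 nM, supplies the one readable pair in this small set and shows that the placement of the pyridine nitrogen alone can move the read-out beyond the usual scatter, though the step is modest and rests on this pair only. Nothing shown here explains why the two pyridines differ.

Steps involving compound 2 and compound 3 cannot be read, as neither carries a number, so it stays open whether the gain from pyridin-4-yl would hold with the chlorine elsewhere on the phenyl ring. The compounds shown also leave open where pyridin-3-yl would fall relative to the two pyridines here, and whether a plain phenyl ring or a ring bearing an amine at this position would keep, lose or extend the step.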